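From Cyanoamino to Diacetylamino on the Shared Core

The source may hold more compounds than are shown below. What is called first, only, known or untested is meant among the compounds shown, and "the series" means these compounds.

Compound 1, `CC(C)(C)c1nc(-c2ccccc2)ncc1-c1ccccc1`, was tested in a functional assay on the whole organism for inhibition, with Rattus norvegicus as the target, with stated times of 1 h and 3.5 h, at a dose of 100 mg/kg by the oral route; a lower number here means less inhibition, a higher number more inhibition at the dose given (going by the name of the read-out). In this assay compound 1 gives < 5%, which is a limit of the assay rather than a number. Compound 2, `CC(C)(C)c1nc(NC#N)ncc1-c1ccccc1`, carries a cyanoamino in place of the phenyl on an aromatic carbon. In this assay compound 2 gives < 5%, again a limit and not a number. The step that the two limits leave unreadable from compound 1 to compound 2 therefore cannot be read, because of the limit of < 5% in this assay, at which 2 of the 2 values shown sit. Compound 2 thus stands at the limit of this assay, with no number known for it and no readable step leading to it.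

Compound 3, `CC(=O)N(C(C)=O)c1ncc(-c2ccccc2)c(C(C)(C)C)n1`, is not yet measured. It differs from compound 2 as follows: diacetylamino in place of cyanoamino on an aromatic carbon. Going by the values given here, only one measured step exists, and it is unreadable, so no measured step bears on this change with a known size. Among the compounds with values here, the only guidance is that compound 2 sits at the limit. Compound 3 is therefore expected to stay near that limit, with a step that the limit leaves unreadable from compound 2 to compound 3 that amounts to nothing beyond the scatter. The estimate for compound 3 in this assay is 3%, with a range from 0% to 12%.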

Compound 3, a percentage reported as inhibition, in the whole organism at one dose (the size of the read-out at that dose, not a potency): 22%
Beside the measured number, compound 3's estimate is 19 percentage points below it; measured number outside the range, above it.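

The position on an aromatic carbon between two ring nitrogen atoms turns out to matter for the shared core, since the group placed there can lift the read-out clear of the limit in this assay. Diacetylamino in place of cyanoamino gives a number at least 17 percentage points higher from compound 2 to compound 3 (beyond the scatter), and diacetylamino in place of phenyl gives a number at least 17 percentage points higher from compound 1 to compound 3 (beyond the scatter), so two quite different groups at this position leave the response at the limit while this one does not. Both steps are only minimum sizes, and their true sizes stay unknown, because one end of each step is a limit and not a number: the limit of < 5% in this assay, at which 2 of the 3 values shown sit.

The compounds shown do not tell whether both acetyl groups are needed, or whether a single acetylamino group, a plain amine or a carboxylic acid at this position would also rise clear of the limit. With a read-out taken at only one dose, they also leave open how the response of compound 3 would change with dose, and so how potent compound 3 is.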